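Pentyl on the ring amine of compound 1

The compounds below may be only part of what the source reports. "The series", "measured", "known", "first", "only" and "open" are said of these compounds alone.

The series is followed in a functional assay on HEK293 cells for agonist activity at 5-hydroxytryptamine receptor 4 (Homo sapiens), read by cAMP accumulation; a lower number here means that less compound is needed, a higher number that more compound is needed for the effect. Compound 1 `COc1cc(N)c(Cl)cc1C(=O)NC1CCNCC1` gives 398 nM. Compound 2 `CC(C)n1c(=O)n(C(=O)NCC2CCNCC2)c2ccccc21` gives 15.9 nM, and compound 3 `CC(C)n1c(=O)n(C(=O)NC2CCNCC2)c2ccccc21` gives 316 nM. Within the data shown here, the single comparable pair shows a 20-fold higher number from compound 2 to compound 3 (1.30 log units; beyond the scatter). Compound 1 stands at the upper end of the three numbers: its gap to compound 3 lies within the scatter, so the two cannot be ordered, while compound 2 sits beyond the scatter below both.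

Compound 4 `CCCCCN1CCC(NC(=O)c2cc(Cl)c(N)cc2OC)CC1` differs from compound 1 by pentyl in place of hydrogen on an amine nitrogen in a ring. Among the measured compounds shown here, no measured step bears on this change: the only step in hand, between compound 2 and compound 3, alters the link on the amide-type nitrogen and leaves the ring amine untouched, and it belongs to a different core. For the measured compounds named here, there is therefore no measured precedent for the direction or the size of the step, and a wide range is the honest statement.

Compound 4 is estimated at 200 nM, with a range from 30 nM to 1500 nM. This amounts to an expected step of a 2.0-fold lower number from compound 1 to compound 4 (0.30 log units; within the scatter), meaning no change beyond the scatter is assumed, with the uncertainty spread to either side.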

Compound 4, half-maximal effective concentration: 25.1 nM
Compound 4: the middle estimate sits 8.0-fold (0.90 log units) above what was measured, outside the stated range (below it).
By their numbers in this assay, from the lowest: compounds 2 and 4 (each within the scatter of the next); then compounds 3 and 1 (each within the scatter of the next).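

In this assay, among these compounds, pentyl in place of hydrogen on the amine nitrogen in the ring gives a 16-fold lower number from compound 1 to compound 4 (1.20 log units; beyond the scatter) and this is the first information on this position, since compounds 1, 2 and 3 all carry hydrogen on that nitrogen. The position therefore accepts a chain of this size on the core of compound 1, and the change moves the number in the lower direction by a large step, making this a second place in the series, after the link on the amide-type nitrogen, where a single change goes beyond the scatter. No evidence on the origin of this step is available.

A single substituent leaves the dependence on the chain open: methyl, propyl, a longer chain such as octyl, or a pentyl chain ending in an amine or a carboxylic acid could each give a different step on the core of compound 1. Also open, from the compounds shown here alone, is whether pentyl on the ring amine of compound 2 or compound 3 would shift the number in the same direction on that other core.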